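This account rests on a few compounds, and the source may have more. Where it says the series, first, only, none or still open, it means among the compounds named here.

Compounds measured in an ADME assay on HEK293 cells (Homo sapiens) for cytotoxicity, read by CellTiter-Glo and resazurin assay, with a stated time of 72 h; a higher number here means that more compound is needed for the effect, a lower number that less compound is needed:

- compound 1, `CCOC(=O)CCCCCOc1cccc(CN(C(=O)c2ccc(-c3cccc(N(C)C)c3)cc2)C(C)C)c1`: > 26000 nM, a limit of the assay.
- compound 2, `CCOC(=O)CCCCCOc1cccc(CN(C(=O)c2ccc(-c3ccoc3)cc2)C(C)C)c1`: > 26000 nM, a limit of the assay.
- compound 3, `CCOC(=O)CCCCCOc1cccc(CN(C(=O)c2ccc(-c3cccc(Oc4ccccc4)c3)cc2)C(C)C)c1`: > 19600 nM, a limit of the assay.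

Compound 3 stands only at a limit in this assay, and the two further values shown are limits as well, so no number places compound 3 against compound 1 or compound 2. Compound 4, `CCOC(=O)CCCCCOc1cccc(CN(C(=O)c2ccc(-c3cccc(-c4nnc(C)o4)c3)cc2)C(C)C)c1`, is not yet measured in this assay. It differs from compound 3 by 5-methyl-1,3,4-oxadiazol-2-yl in place of phenoxy on an aromatic carbon. Among the compounds with values here, two measured steps bear on a change at this position of the core: a step that the two limits leave unreadable from compound 1 to compound 3 and a step that the two limits leave unreadable from compound 1 to compound 2. Neither has a readable size, since the values on both sides sit at the limit of > 26000 nM in this assay, at which 2 of the 3 values shown sit, or at the limit of > 19600 nM in this assay, at which 1 of the 3 values shown sits. Across the three measured compounds, exchanging the group on this aromatic carbon has not brought the read-out in this assay below a limit, and there is no basis for expecting a step beyond the scatter from compound 3 to compound 4. Compound 4 is therefore expected at 30000 nM, with a range from 12000 nM to 80000 nM, an estimated step that the limit leaves unreadable from compound 3 to compound 4, and most likely to be reported only as a limit.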

Compound 4, half-maximal effective concentration: > 26000 nM
Compound 4 ended at the assay's limit; the forecaster's own chance of this, stated with the estimate: 80%; the middle value does not contradict the limit.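

In this assay compound 4 gives > 26000 nM, a limit of the assay. The steps to compound 4 from compound 1, compound 2 and compound 3 cannot be read: all four values are limits. The compounds shown leave open whether any group at this position of the shared core gives a numerical half-maximal effective concentration in this assay.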